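Replacing pentafluorophenyl on the carbonyl: compound 1 to compound 4

A few compounds are considered here, and "the series" means these few. Any claim that something is new, unique, unknown or untested is made for them only; others in the source may bear on it.

Measured in a functional assay on DU-145 cells (Homo sapiens) for inhibition, read by trypan blue exclusion, with a stated time of 96 h (a higher number here means a weaker inhibitor of growth, a lower number a stronger inhibitor of growth), as follows
compound 1 `O=C(/C(=C\c1ccc(O)c([N+](=O)[O-])c1)SCc1ccc(Br)cc1)c1c(F)c(F)c(F)c(F)c1F` gives 10000 nM
compound 2 `COc1ccccc1/C=C(/SCc1ccc(Cl)c(Cl)c1)C(=O)c1ccc(Cl)cc1` gives 10000 nM
compound 3 `O=C(/C(=C\c1ccc(O)c([N+](=O)[O-])c1)S(=O)(=O)Cc1ccc(Br)cc1)c1c(F)c(F)c(F)c(F)c1F` gives 50000 nM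

Compound 1 stands level with compound 2 at the lowest number of the three, and only compound 3 lies higher. The change to compound 4 `O=C(/C(=C\c1ccc(O)c([N+](=O)[O-])c1)SCc1ccc(Br)cc1)c1ccc(O)cc1O` puts 2,4-dihydroxyphenyl in place of 2,3,4,5,6-pentafluorophenyl on a carbonyl carbon. Among the compounds with values here, the only measured step (a 5.0-fold higher number from compound 1 to compound 3 (0.70 log units; beyond the scatter)) is beyond the scatter, but it puts (4-bromobenzyl)sulfonyl in place of (4-bromobenzyl)sulfanyl and leaves the group on the carbonyl carbon untouched. Within the data shown here, its size serves only as a loose guide to the width of the range, and no measured step gives a direction for the new change. In this assay no shift beyond the scatter is expected, so the estimated step (no change at the digits printed from compound 1 to compound 4 (within the scatter)) carries wide uncertainty in either direction. Compound 4 is expected at 10000 nM within an estimated range (2500 nM to 40000 nM).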

Compound 4, concentration for 50% growth inhibition: > 100000 nM
Compound 4 ended at the assay's limit (the forecaster's own chance of this, stated with the estimate: 15%); middle value at least 10-fold (1.00 log units) from the limit.
By their numbers in this assay, from the lowest: compounds 1 and 2 (each within the scatter of the next); then compound 3. At a limit, above all of these: compound 4.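

In this assay, the group on the carbonyl carbon proves not to be a silent position: with the rest of the structure unchanged, 2,4-dihydroxyphenyl in place of 2,3,4,5,6-pentafluorophenyl gives an at least 10-fold higher number from compound 1 to compound 4 (1.00 log units; beyond the scatter). Compound 4 stands at a limit of the assay, so this step has only a lower bound: the limit of > 100000 nM in this assay, at which 1 of the 4 values shown sits. Both changes measured from compound 1 now go to a higher number, this one and the (4-bromobenzyl)sulfonyl change in compound 3, although they lie at different places.

The exchange removes fluorine and adds hydroxyl together, so the compounds shown cannot separate the two, and an unsubstituted phenyl, a single hydroxyl or a methoxy group on this ring would be needed to do so. Also open, on these data alone, is whether any group at this place gives a lower number than compound 1 at 10000 nM.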